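Replacing hydroxy with pyridin-2-yl: notes on the series

The compounds below may be only part of what the source reports. "The series", "measured", "known", "first", "only" and "open" are said of these compounds alone.

compound 1 `O=C(CCCCC(S)CCS)NO` gives 1.17% 
compound 2 `COc1ccc(NC(=O)CCCCC(S)CCS)cc1` gives "not active" (no number reported) 

Both results come from a functional assay on NCI-H460 cells (Homo sapiens) for inhibition, read by MTT assay, with a stated time of 24 h, tested at 1 ug/mL (a higher number here means more inhibition of growth at the concentration tested, a lower number less inhibition of growth), and give little to work from. Within the data shown here, compound 1 holds the only number, 1.17%, which sits close to no inhibition of growth at the concentration tested. Among the measured compounds shown here, compound 2 gives no number and is reported as "not active" (no number reported) in the same test, so no step between measured compounds can be stated.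

Compound 3 `O=C(CCCCC(S)CCS)Nc1ccccn1` has not yet been measured in this assay and shares the rest of its structure with compound 1. The difference is pyridin-2-yl in place of hydroxy on an amide-type nitrogen.

The expectation rests on compound 1 at 1.17% and on compound 2 at "not active" (no number reported) with a ring also in place of the hydroxy. Neither result points to a clear gain. The estimated step of a number 1.8 percentage points higher from compound 1 to compound 3 (within the scatter) is expected to stay within the usual scatter, with no firm direction. A report without a number is also possible. Compound 3 is estimated at 3% with an expected range from 0% to 15% in this test.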

Compound 3, percent growth inhibition at one concentration: 2.31%
The estimate for compound 3 lay 0.7 percentage points above the measured number, and the stated range covers the measured number.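

Among these compounds, the change from hydroxy to pyridin-2-yl on the amide-type nitrogen gives the first readable step at this position in this assay, and that step, a number 1.1 percentage points higher from compound 1 to compound 3 (within the scatter), carries no direction. A group of 6 heavy atoms with a six-membered aromatic ring and no hydrogen-bond donor thus takes the place of a hydroxy of 1 heavy atom, and the result remains close to no inhibition of growth at the concentration tested, so this exchange neither gains nor loses a measurable effect. Nothing at hand explains this outcome or bears on what the exchange does at this position.

Any step to compound 2 cannot be read, since it carries no number, so the series rests on a single step between two compounds that both lie near the bottom of the read-out. As far as these compounds go, it remains open whether any other group on this nitrogen, such as a longer chain ending in an amine or a carboxylic acid, would move growth inhibition clear of the scatter.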